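Methoxy for Methyl: Expected Cytotoxicity of Compound 4

The source may report more compounds than this note shows. Statements on the series, on what has been measured and on what is new or still open speak of the compounds shown alone.

Compound 3 `Cc1ccc(-c2cn(C[C@H](O)[C@H]3OC(=O)C(OCc4ccccc4)=C3OCc3ccccc3)nn2)cc1` is one of three close relatives tested in an ADME assay on HFF cells (Homo sapiens) for cytotoxicity, read by MTT assay, with a stated time of 72 h; a higher number here means a weaker inhibitor, a lower number a stronger inhibitor. In this assay compound 3 gives > 100000 nM, which is a limit of the assay rather than a measured number. Compound 2 `CCCCCCCCCCc1cn(C[C@H](O)[C@H]2OC(=O)C(OCc3ccccc3)=C2OCc2ccccc2)nn1` likewise reaches only a limit, giving > 100000 nM in this assay. Compound 1 `O=C1O[C@H]([C@@H](O)Cn2cc(-c3cccc(O)c3)nn2)C(OCc2ccccc2)=C1OCc1ccccc1` gives 39000 nM in this assay. Going from compound 1 to compound 3 means an at least 2.5-fold higher number from compound 1 to compound 3 (0.40 log units; beyond the scatter), and the step of an at least 2.5-fold higher number from compound 1 to compound 2 (0.40 log units; beyond the scatter) is of the same kind, while the pair of compound 2 and compound 3 gives a step that the two limits leave unreadable from compound 2 to compound 3. That picture reflects (the limit of > 100000 nM in this assay, at which 2 of the 3 values shown sit).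

Compound 4 `COc1ccc(-c2cn(C[C@H](O)[C@H]3OC(=O)C(OCc4ccccc4)=C3OCc3ccccc3)nn2)cc1` differs from compound 3 by methoxy in place of methyl on an aromatic carbon. Among the measured compounds shown here, the only readable steps at this part of the molecule, both starting from compound 1, went toward weaker inhibition, and the nearest neighbour of compound 4 sits at a limit. Compound 4 is therefore expected to show no step beyond the scatter, a number no higher from compound 3 to compound 4 (the limit leaves the size open). The expected value for compound 4 is 100000 nM, with a range from 40000 nM to 300000 nM, and most likely the assay will again report only a limit.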

Compound 4, half-maximal inhibitory concentration: < 10 nM
Compound 4: a limit, no number; the forecaster's own chance of this, stated with the estimate: 70%; middle value at least 10000-fold (4.00 log units) from the limit.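

Methoxy in place of methyl, on an aromatic carbon para to a large group, gives an at least 10000-fold lower number from compound 3 to compound 4 (4.00 log units; beyond the scatter) in this assay, so this one small change can matter enormously at this position. The earlier readable steps here all went toward higher numbers, whereas compound 4 goes sharply the other way, with an at least 10000-fold lower number from compound 2 to compound 4 (4.00 log units; beyond the scatter) and an at least 3900-fold lower number from compound 1 to compound 4 (3.59 log units; beyond the scatter). These steps give minimum sizes rather than exact ones because compound 4 sits at a limit: the limit of < 10 nM in this assay, at which 1 of the 4 values shown sits.

Going by these compounds, it remains open whether the oxygen alone carries this step or whether the group attached to it also matters, and an ethoxy or a hydroxyl group at the same place would separate the two. On these data alone, the true value of compound 4 also remains unknown, as does whether this single sharp change belongs to any wider pattern.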